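A few compounds are considered here, and "the series" means these few. Any claim that something is new, unique, unknown or untested is made for them only; others in the source may bear on it.

Of the compounds shown here, three with a shared tail have been tested, and a fourth has not yet been run. Compound 1 has the structure `CCCC[C@@H](O)C(=O)N1C[C@H]2C[C@H]2[C@H]1C(=O)NCc1cc(Cl)ccc1-n1cnnn1` and in a functional assay on a cell-free system (plasma, Homo sapiens), with a stated time of 3 min (on this read-out lower numbers stand for stronger inhibition and higher numbers for weaker inhibition), compound 1 gives 750 nM. Compound 2 has the structure `COC(C)(C)[C@@H](O)C(=O)N1C[C@H]2C[C@H]2[C@H]1C(=O)NCc1cc(Cl)ccc1-n1cnnn1` and in this assay compound 2 gives 1000 nM. Among the measured compounds shown here, the only change between them is 1-methoxy-1-methylethyl in place of butyl on a saturated chain carbon bound to a carbonyl carbon and an oxygen on a saturated carbon, and it made a step of a 1.3-fold higher number from compound 1 to compound 2 (0.12 log units; within the scatter). Compound 3 has the structure `CCCC[C@@H](O)C(=O)N1N=CC[C@H]1C(=O)NCc1cc(Cl)ccc1-n1cnnn1`, built on a different core; the difference between the two cores is not broken down here. In this assay compound 3 gives 610 nM, a number close to that of compound 1 and of compound 2. Compound 4 has the structure `COC(C)(C)[C@@H](O)C(=O)N1N=CC[C@H]1C(=O)NCc1cc(Cl)ccc1-n1cnnn1` and carries the same change on the core of compound 3, namely (1-methoxy-1-methylethyl in place of butyl on a saturated chain carbon bound to a carbonyl carbon and an oxygen on a saturated carbon), at the same place as before. For compound 4 the step from compound 3 is expected to be a 1.3-fold higher number from compound 3 to compound 4 (0.12 log units; within the scatter), a size that rests on a 1.3-fold higher number from compound 1 to compound 2 (0.12 log units; within the scatter) seen with compound 1 and compound 2. Compound 4 is therefore estimated at 800 nM, with a likely range from 400 nM to 1600 nM.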

Compound 4, half-maximal inhibitory concentration: 3700 nM
For compound 4 the middle estimate is 4.6-fold (0.67 log units) below the measured one; the measured number lies above the stated range.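

In this assay, placing 1-methoxy-1-methylethyl where butyl stood gives a much larger loss of inhibition on the core of compound 3 than on the core of compound 1, with a 6.1-fold higher number from compound 3 to compound 4 (0.78 log units; beyond the scatter). Set side by side, the two steps do not agree, so in this series the size of this change did not carry over from one core to the other: the same change on two cores in this assay, a 1.3-fold higher number (0.12 log units; within the scatter) from compound 1 to compound 2 and a 6.1-fold higher number (0.78 log units; beyond the scatter) from compound 3 to compound 4, 4.5-fold (0.66 log units) apart, beyond the scatter of two such steps. This rests on a single change tested on just two cores, so it does not show why the cores respond differently, or whether other groups at this place would behave in the same way.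

The compounds shown leave open which part of the new group goes with the larger step on the core of compound 3. A tert-butyl group, which keeps the branched carbon without the oxygen, or a straight chain ending in methoxy, compared on both cores, would help to separate the two.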